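A few compounds are considered here, and "the series" means these few. Any claim that something is new, unique, unknown or untested is made for them only; others in the source may bear on it.

Compounds measured in an assay on CHO cells for displacement of a labelled ligand from adenosine receptor A1 (Homo sapiens), read by scintillation counting, with a stated time of 90 min, in the presence of a further agent that is not named here; a lower number here means a stronger inhibitor, a higher number a weaker inhibitor:
compound 1 `CCCn1c(=O)[nH]c2nc(-c3ccc(S(=O)(=O)N4CCN(c5ccccc5C)CC4)cc3)[nH]c2c1=O` gives 419 nM;
compound 2 `CCCn1c(=O)[nH]c2nc(-c3ccc(S(=O)(=O)N4CCN(C)CC4)cc3)[nH]c2c1=O` gives 334 nM;
compound 3 `CCCn1c(=O)[nH]c2nc(-c3ccc(S(=O)(=O)N4CCN(c5ccccc5Br)CC4)cc3)[nH]c2c1=O` gives > 1000 nM, a limit of the assay and not a number.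

Compound 3 sits at the limit of > 1000 nM in this assay, at which 1 of the 3 values shown sits, so its position within the series is known only as a bound. Between compound 1 and compound 2 the step is a 1.3-fold lower number from compound 1 to compound 2 (0.10 log units; within the scatter). Toward compound 3 both steps run the same way: an at least 2.3-fold higher number from compound 1 to compound 3 (0.37 log units; beyond the scatter) and an at least 2.9-fold higher number from compound 2 to compound 3 (0.47 log units; beyond the scatter).

Compound 4 `CCCn1c(=O)[nH]c2nc(-c3ccc(S(=O)(=O)N4CCN(Cc5ccc(Br)cc5)CC4)cc3)[nH]c2c1=O` is not yet measured. It differs from compound 3 as follows: 4-bromobenzyl in place of 2-bromophenyl on an amine nitrogen in a ring. Going by the values given here, no measured pair covers this change directly. Among the compounds with values here, the only steps that touch the same ring nitrogen are an at least 2.9-fold higher number from compound 2 to compound 3 (0.47 log units; beyond the scatter) and an at least 2.3-fold higher number from compound 1 to compound 3 (0.37 log units; beyond the scatter), both showing a weaker result once a brominated aryl group sits there. Compound 2, with methyl on that nitrogen, stands at 334 nM; compound 4 carries a larger substituent there, so the number is expected to fall between these poles.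

Compound 4 is expected to give 700 nM in this assay, within 250 nM to 2000 nM, an expected step of an at least 1.4-fold lower number from compound 3 to compound 4 (0.15 log units; that floor lies within the scatter).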

Compound 4, inhibition constant: > 1000 nM
Compound 4: no number, only a limit (the forecaster's own chance of this, stated with the estimate: 35%); middle value at least 1.4-fold (0.15 log units) from the limit.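

In this assay compound 4 gives > 1000 nM, a limit of the assay and not a number. Both readable steps run the same way, an at least 2.9-fold higher number from compound 2 to compound 4 (0.47 log units; beyond the scatter) and an at least 2.3-fold higher number from compound 1 to compound 4 (0.37 log units; beyond the scatter), so on the ring nitrogen a weaker result goes with 4-bromobenzyl as well as with 2-bromophenyl, while the methyl and 2-methylphenyl groups of compound 2 and compound 1 keep measurable values. The step between the two brominated compounds cannot be read, and each stays known only as a bound: the limit of > 1000 nM in this assay, at which 2 of the 4 values shown sit.

Open, as far as these compounds go, is whether the bromine or the aryl group itself goes with the weaker result; a plain benzyl or a 4-methoxybenzyl group on that nitrogen would separate these. From the compounds shown here alone, how far compound 3 and compound 4 lie beyond the limit also remains unknown.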